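Toward Compound 4: Cytotoxicity Where Every Value Is a Limit

The source may hold more compounds than are shown below. What is called first, only, known or untested is meant among the compounds shown, and "the series" means these compounds.

Of the compounds shown here, three that share one core have been tested in an ADME assay on THP-1 cells (Homo sapiens) for cytotoxicity, read by MTT assay, with a stated time of 72 h; a higher number here means that more compound is needed for the effect, a lower number that less compound is needed. Compound 1 `Cc1cncc(-c2ccc3[nH]c(=O)nc(-c4ccccc4)c3c2)c1` is the starting point of this account. In this assay compound 1 gives > 50000 nM, which is a limit of the assay rather than a measured number. Compound 2 `O=c1nc(-c2ccccc2)c2ccc(-c3ccncc3)cc2[nH]1` gives > 50000 nM, again a limit. Compound 3 `N#Cc1ccc(-c2cccc3[nH]c(=O)nc(-c4ccccc4)c23)cc1` likewise gives > 50000 nM, also a limit. Compound 1 therefore stands nowhere distinct among the numbers shown: all three sit at the limit of > 50000 nM in this assay, at which 3 of the 3 values shown sit, so none of them can be ranked against another, and no step between measured compounds can be drawn.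

Compound 4 `CN1CCN(c2ccc3[nH]c(=O)nc(-c4ccccc4)c3c2)CC1` has not yet been measured in this assay. It differs from compound 1 in one place: 4-methylpiperazin-1-yl in place of 5-methylpyridin-3-yl on an aromatic carbon. With every measured value resting at a limit, there is no measured step on which to build, and the structural change by itself gives no measured reason to expect the read-out to move in either direction. The expectation is that the step of a number no higher from compound 1 to compound 4 (the limit leaves the size open) amounts to none beyond the usual scatter. Compound 4 is expected to give about 50000 nM in this assay, inside a range from 20000 nM to 150000 nM, and most probably to come back once more as only a limit.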

Compound 4, half-maximal effective concentration: > 50000 nM
Compound 4 gave a limit, no number; the forecaster's own chance of this, stated with the estimate: 80%; the middle value lies on the limit itself.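

Among these compounds, compound 4, like compound 1, returns only a limit and not a number, so no step between compound 1 and compound 4 can be read in this assay: the limit of > 50000 nM in this assay, at which 4 of the 4 values shown sit.

The compounds shown leave open at what concentration any of the four reaches the half-maximal effect, and whether 4-methylpiperazin-1-yl in place of 5-methylpyridin-3-yl shifts that concentration at all.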